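The source may hold more compounds than are shown below. What is called first, only, known or untested is meant among the compounds shown, and "the series" means these compounds.

In a functional assay on A549 cells (Homo sapiens) for cytotoxicity, read by MTT assay, with a stated time of 72 h (on this read-out lower numbers stand for stronger inhibition and higher numbers for weaker inhibition), compound 1 `Cc1ccc(C(=O)Nc2nnc(-c3ccc(O)c(O)c3)s2)cc1` gives 11800 nM. Compound 2 `O=C(Nc1nnc(-c2ccc(O)c(O)c2)s1)C1CCCCC1` differs from compound 1 by cyclohexyl in place of 4-methylphenyl on a carbonyl carbon, and in this assay compound 2 gives 16300 nM, which means a 1.4-fold higher number from compound 1 to compound 2 (0.14 log units; within the scatter). Compound 3 `Cc1ccc(C(=O)Nc2nnc(-c3cccc(O)c3O)s2)cc1` is built from the same atoms as compound 1, joined differently; the difference between the two cores is not broken down here. In this assay compound 3 gives 11300 nM. Compound 4 `O=C(Nc1nnc(-c2cccc(O)c2O)s1)C1CCCCC1` has not yet been measured. It differs from compound 3 by cyclohexyl in place of 4-methylphenyl on a carbonyl carbon, the same change that was made from compound 1 to compound 2. Because a 1.4-fold higher number from compound 1 to compound 2 (0.14 log units; within the scatter) stayed within the usual scatter, an expected step of similar size is a 1.3-fold higher number from compound 3 to compound 4 (0.12 log units; within the scatter). The estimate for compound 4 in this assay is 15000 nM, expected to fall between 8000 nM and 30000 nM.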

Compound 4, half-maximal inhibitory concentration: 11000 nM
Compound 4: the middle estimate sits 1.4-fold (0.13 log units) above what was measured, and the stated range covers the measured number.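

In this assay, putting cyclohexyl in place of 4-methylphenyl on a carbonyl carbon gives a 1.0-fold lower number from compound 3 to compound 4 (0.01 log units; within the scatter). The same change on the core of compound 1 gives a step that agrees with this one as far as such measurements can tell: the same change on two cores in this assay, a 1.4-fold higher number (0.14 log units; within the scatter) from compound 1 to compound 2 and a 1.0-fold lower number (0.01 log units; within the scatter) from compound 3 to compound 4, 1.4-fold (0.15 log units) apart, within the scatter of two such steps. On these two cores, the change carries over with no step beyond the usual scatter, but two small steps in a single cell assay cannot show that it would behave the same way on any other core.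

The compounds shown leave open what an amine or a longer carbon chain would give in place of the ring on the carbonyl carbon.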